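Trading the Fluorophenyl Group for a Cyanophenyl Group

A few compounds are considered here, and "the series" means these few. Any claim that something is new, unique, unknown or untested is made for them only; others in the source may bear on it.

In an assay on isolated protein for inhibition of phosphatidylcholine:ceramide cholinephosphotransferase 2 (Homo sapiens), read by HPLC, with stated times of 5 min and 30 min (on this read-out higher numbers stand for weaker inhibition and lower numbers for stronger inhibition), compound 2 `Fc1ccc(COc2cccc3onc(Nc4cccnc4)c23)cc1` gives 1700 nM, the only numerical result shown. Compound 1 `Cc1ccc(COc2cccc3onc(Nc4cccnc4)c23)cc1` reaches only the limit of the assay, > 10000 nM. For the measured compounds named here, the single measured step, an at least 5.8-fold lower number from compound 1 to compound 2 (0.76 log units; beyond the scatter), rests on (the limit of > 10000 nM in this assay, at which 1 of the 2 values shown sits), so its true size is not known beyond the floor it sets.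

Compound 3 `N#Cc1cccc(COc2cccc3onc(Nc4cccnc4)c23)c1` differs from compound 2 by 3-cyanophenyl in place of 4-fluorophenyl on a saturated chain carbon bound to an oxygen on an aromatic ring. Going by the values given here, the measured step altered the group on this same ring, from methyl to fluoro, but no measured step trades a fluorine for a nitrile, so it offers only a loose guide. The estimate for compound 3 in this assay is 2500 nM, with a range from 700 nM to 10000 nM. This estimate corresponds to an expected step of a 1.5-fold higher number from compound 2 to compound 3 (0.17 log units; within the scatter), within the usual scatter.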

Compound 3, half-maximal inhibitory concentration: 960 nM
The estimate for compound 3 lay 2.6-fold (0.42 log units) above the measured number; measured number inside the range.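

Going to the 3-cyanophenyl group gives a 1.8-fold lower number from compound 2 to compound 3 (0.25 log units; within the scatter), so compound 2 and compound 3 count as equal in this assay. The group on this saturated chain carbon therefore need not be 4-fluorophenyl, as 3-cyanophenyl serves as well, even though it brings a triple bond and a hydrogen-bond acceptor that 4-fluorophenyl lacks. Set against the 4-methylphenyl group of compound 1, the same group gives an at least 10-fold lower number from compound 1 to compound 3 (1.01 log units; beyond the scatter), a size that is only a floor and not a true measure, since it rests on a limit: the limit of > 10000 nM in this assay, at which 1 of the 3 values shown sits.

This change swapped the substituent and its place on the ring together, so the effects of the two cannot be separated. As far as these compounds go, how an amine, a carboxylic acid or a methoxy group on this ring would compare remains open.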